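Acetamide series on protein kinase C zeta: piperazine extension

This account rests on a few compounds, and the source may have more. Where it says the series, first, only, none or still open, it means among the compounds named here.

Compound 1 `Cn1nc(N)c2c(=O)[nH]c(-c3ccccc3)cc21` and compound 2 `CC(=O)Nc1nn(C)c2cc(-c3ccccc3)[nH]c(=O)c12` share one core and have both been run in an assay on isolated protein for inhibition of protein kinase C zeta type (Homo sapiens), read by mobility shift assay, tested at 30 uM; on this read-out higher numbers stand for more inhibition at the one concentration tested (going by the name of the read-out) and lower numbers for less inhibition. Compound 1 gives 6% and compound 2 gives 28%. Among the compounds with values here, the one step measured so far, a number 22 percentage points higher from compound 1 to compound 2 (beyond the scatter), is the only movement seen in this assay, and on it compound 2 stands highest of the two numbers, with compound 1 the nearest number and beyond the scatter below it. Compound 3 `CC(=O)Nc1nn(C)c2cc(-c3ccc(N4CCN(C)CC4)cc3)[nH]c(=O)c12` differs from compound 2 by 4-methylpiperazin-1-yl in place of hydrogen on an aromatic carbon. Within the data shown here, no measured step bears on this change; the only step, a number 22 percentage points higher from compound 1 to compound 2 (beyond the scatter), concerns the acetyl on the ring nitrogen and says nothing about the phenyl ring. Expectation is therefore a small upward step, a number 7 percentage points higher from compound 2 to compound 3 (within the scatter), expected but not beyond the scatter. Compound 3 is estimated at 35%, in the range 10% to 65%.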

Compound 3, a percentage reported as inhibition, at one concentration (the size of the read-out at that concentration, not a potency): 6%
The estimate for compound 3 lay 29 percentage points above the measured number, and the stated range ends above it.
By their numbers in this assay, from the lowest: compounds 1 and 3 (each within the scatter of the next); then compound 2.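

In this assay, within the data shown here, the first measured change on the six-membered aromatic ring of carbon only gives a number 22 percentage points lower from compound 2 to compound 3 (beyond the scatter), so this position is not indifferent to substitution. Hydrogen can be exchanged here for 4-methylpiperazin-1-yl only at a cost in inhibition at the one concentration tested, and the change adds one six-membered non-aromatic ring with 2 hetero atoms. Nothing available on the compounds accounts for this loss.

As far as these compounds go, it remains open whether the loss belongs to the piperazine ring itself or to any large group at this place; a morpholine, a dimethylamino group or a methoxy group on the same carbon would separate the two. From the compounds shown here alone, the effect of a carboxylic acid or a longer chain ending in an amine at this place also remains open.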